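A few compounds are considered here, and "the series" means these few. Any claim that something is new, unique, unknown or untested is made for them only; others in the source may bear on it.

The measured compounds are compound 1 `COc1ccc(NC(=S)Nn2c(S)nnc2-c2ccncc2)cc1` at 2370 nM, compound 2 `Cc1ccc(NC(=S)Nn2c(S)nnc2-c2ccncc2)cc1` at 2380 nM and compound 3 `COc1ccc(Nc2nn3c(-c4ccncc4)nnc3s2)cc1` at 282 nM.

All three were tested in a functional assay on HA22T cells (Homo sapiens) for cytotoxicity, read by sulforhodamine B assay, with a stated time of 24 h; a higher number here means a weaker inhibitor, a lower number a stronger inhibitor. Compound 1 and compound 2 share one core and differ only in methyl in place of methoxy on an aromatic carbon. That change produced a 1.0-fold higher number from compound 1 to compound 2 (0.00 log units; within the scatter), so the two values show no separation that could be read as a difference. Compound 3 carries a different core; how the two cores differ is not broken down here. In this assay compound 3 gives 282 nM, the lowest of the three numbers, and its steps to compound 1 and to compound 2 both lie beyond the scatter, so among the measured compounds it is the strongest inhibitor.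

Compound 4 `Cc1ccc(Nc2nn3c(-c4ccncc4)nnc3s2)cc1` has not yet been measured. It differs from compound 3 in methyl in place of methoxy on an aromatic carbon. This is the same change that separates compound 1 from compound 2, made at a place described in the same words, and on that pair it moved the number by nothing that the scatter would not cover. The expectation for compound 4 rests on that: the step of a 1.1-fold higher number from compound 3 to compound 4 (0.03 log units; within the scatter) is expected to stay within the scatter, because the earlier step of a 1.0-fold higher number from compound 1 to compound 2 (0.00 log units; within the scatter) did. Compound 4 is therefore estimated at 300 nM in this assay, with a range from 150 nM to 600 nM.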

Compound 4, half-maximal inhibitory concentration: 277 nM
For compound 4 the middle estimate is 1.1-fold (0.03 log units) above the measured one, and the stated range covers the measured number.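

In this assay, putting methyl in place of methoxy on an aromatic carbon of the six-membered aromatic ring of carbon only, para to a large group, gave a 1.0-fold lower number from compound 3 to compound 4 (0.01 log units; within the scatter), so the two values show no separation that could be read as a difference. Set beside the earlier step, the exchange of these two groups reads the same on both cores, with no gap between the steps that exceeds what repeated measurement would give: the same change on two cores in this assay, a 1.0-fold higher number (0.00 log units; within the scatter) from compound 1 to compound 2 and a 1.0-fold lower number (0.01 log units; within the scatter) from compound 3 to compound 4, 1.0-fold (0.01 log units) apart, within the scatter of two such steps This shows only that, on these two cores and in this one cell assay, methoxy and methyl at this place can stand in for each other without a readable change in the number; it does not show that the same would hold on a third core, for any other pair of groups, or at any other place on the ring.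

The compounds shown leave open how the number would respond at this same place to a group of another kind, such as an amine, a carboxylic acid, chlorine or a longer chain like butoxy. They also leave open whether the exchange of methoxy for methyl would stay as silent in a different cell line or over a different exposure time.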